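The source may report more compounds than this note shows. Statements on the series, on what has been measured and on what is new or still open speak of the compounds shown alone.

Measured so far:
- compound 1 `CN(C)/[N+]([O-])=N/Oc1cc(O/N=[N+](\[O-])N2CCCC2)c([N+](=O)[O-])cc1[N+](=O)[O-]`: 4900 nM
- compound 2 `CN(C)/[N+]([O-])=N/Oc1cc(O/N=[N+](\[O-])N2CCCC2CO)c([N+](=O)[O-])cc1[N+](=O)[O-]`: 2000 nM

In a functional assay on HL-60 cells (Homo sapiens) for antiproliferative activity, read by MTT assay, with a stated time of 72 h (on this read-out higher numbers stand for weaker inhibition of growth and lower numbers for stronger inhibition of growth), compound 2 stands lowest of the two values, with compound 1 the nearer neighbour. Compound 3 `CCN(CC)/[N+]([O-])=N/Oc1cc(O/N=[N+](\[O-])N(C)C)c([N+](=O)[O-])cc1[N+](=O)[O-]` differs from compound 2 by diethylamino in place of 2-(hydroxymethyl)pyrrolidin-1-yl on a double-bonded nitrogen. Going by the values given here, the one step that bears on it is a 2.5-fold lower number from compound 1 to compound 2 (0.39 log units; beyond the scatter), which added the hydroxymethyl now being removed. With the hydroxymethyl lost and the ring replaced by an acyclic group of comparable size, a modest rise back toward compound 1 is expected, a 2.0-fold higher number from compound 2 to compound 3 (0.30 log units; within the scatter). Compound 3 is therefore estimated at 4000 nM (range 1500 nM to 11000 nM).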

Compound 3, concentration for total growth inhibition: 2300 nM
For compound 3 the middle estimate is 1.7-fold (0.24 log units) above the measured one; the range from low to high includes it.
By their numbers in this assay, from the lowest: compounds 2 and 3 (each within the scatter of the next); then compound 1.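

In this assay, a 1.2-fold higher number from compound 2 to compound 3 (0.06 log units; within the scatter), so on this double-bonded nitrogen an open-chain diethylamino with no hydroxymethyl matches 2-(hydroxymethyl)pyrrolidin-1-yl, and neither the ring nor the hydroxyl is required for that level. Against plain pyrrolidin-1-yl, a 2.1-fold lower number from compound 1 to compound 3 (0.33 log units; beyond the scatter), so hydroxymethyl is not the only change that separates a compound from compound 1. No measurement on hand accounts for these values. Still open, going by these compounds, is whether a longer chain such as dipropylamino on this nitrogen, or methoxymethyl in place of hydroxymethyl, would depart from compound 2 beyond the scatter.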